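The source may report more compounds than this note shows. Statements on the series, on what has been measured and on what is new or still open speak of the compounds shown alone.

Compound 3 `Nc1ccc(S(=O)(=O)N2CC(n3cc(F)c(=O)[nH]c3=O)OCc3ccccc32)cc1` was tested in a functional assay on MCF7 cells (Homo sapiens) for antiproliferative activity (a lower number here means a stronger inhibitor, a higher number a weaker inhibitor), where compound 3 gives 14400 nM. Among the compounds shown it is the only one reported as a single number. Compound 1 `COC(CN(c1ccccc1CO)S(=O)(=O)c1ccccc1[N+](=O)[O-])n1cnc2c(Cl)ncnc21` has two entries in this assay, and compound 1 gives 11300 nM; 3250 nM (2 entries). Compound 2 `COC(CN(c1ccccc1CO)S(=O)(=O)c1ccccc1N)n1cc(F)c(=O)[nH]c1=O` reached only the limit of this assay, and compound 2 is recorded as > 100000 nM; that is a limit, not a number. Compound 4 `Nc1ccccc1S(=O)(=O)N1CC(n2cc(F)c(=O)[nH]c2=O)OCc2ccccc21` has not yet been measured. It differs from compound 3 in one place: 2-aminophenyl in place of 4-aminophenyl on a sulfonyl sulfur. Within the data shown here, no step between two measured compounds carries this change, so there is nothing in the data to set it against. For compound 4 the expected step is a 1.0-fold higher number from compound 3 to compound 4 (0.02 log units; within the scatter), which should stay within the scatter of repeated measurements, in neither direction. On that basis compound 4 is expected to give about 15000 nM, within a range from 5000 nM to 50000 nM.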

Compound 4, half-maximal inhibitory concentration: 54800 nM
Beside the measured number, compound 4's estimate is 3.7-fold (0.56 log units) below it, and the stated range ends below it.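

Replacing 4-aminophenyl with 2-aminophenyl on the sulfonyl sulfur changes the result in this assay, even though the two compounds have the same atoms joined differently: the change gives a 3.8-fold higher number from compound 3 to compound 4 (0.58 log units; beyond the scatter). Among these compounds, no earlier pair isolated a single change, so this is the first sign here that where the amino group sits on this ring can alter the measured number. The step is modest, and entries for one compound can also differ, so a single step calls for caution: the several entries of compound 1 in this assay, 11300 nM; 3250 nM (2 entries)

The compounds shown leave open whether the amino group itself matters here, which a plain phenyl group or a 4-hydroxyphenyl group at the same place on the sulfonyl sulfur could test. They also leave open whether the same change would give a similar step on a different core.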